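This account rests on a few compounds, and the source may have more. Where it says the series, first, only, none or still open, it means among the compounds named here.

Measured compounds:
Compound 1, `[O-][S+](Cc1ccc(Cl)s1)C(c1ccccc1)c1ccccc1`: 12800 nM
Compound 2, `[O-][S+](Cc1cccs1)C(c1ccc(Cl)cc1)c1ccc(Cl)cc1`: 7200 nM
Compound 3, `[O-][S+](Cc1nc(O)cc(C(F)(F)F)n1)C(c1ccccc1)c1ccccc1`: 40400 nM

In an assay on HEK293 cells for inhibition of sodium-dependent dopamine transporter (Homo sapiens), read by scintillation counting, with stated times of 5 min and 1 min (on this read-out higher numbers stand for weaker inhibition and lower numbers for stronger inhibition), compound 1 gives 12800 nM, the second highest of the three numbers measured. Compound 2, with 7200 nM, lies within the usual scatter of compound 1, so the two cannot be told apart on these data. Compound 3, with 40400 nM, gives a higher number than compound 1, and that gap is beyond the scatter, so compound 3 is the weaker inhibitor of the two.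

Compound 4, `[O-][S+](Cc1cc(Br)cs1)C(c1ccccc1)c1ccccc1`, has not yet been measured in this assay. Compared with compound 1 the change is 4-bromothiophen-2-yl in place of 5-chlorothiophen-2-yl on a saturated chain carbon bound to a sulfur. The thiophene ring and the diphenylmethyl part of the shared core are kept; only the halogen and its position on the thiophene differ. For the measured compounds named here, no measured pair in this set shows the effect of such a change, so the expectation rests on the small size of the swap alone.

Compound 4 is expected to give about 12000 nM in this assay. The estimate spans from 5000 nM to 30000 nM. The step this estimate means is a 1.1-fold lower number from compound 1 to compound 4 (0.03 log units; within the scatter), expected to stay within the scatter rather than move clearly in either direction.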

Compound 4, half-maximal inhibitory concentration: 13700 nM
Compound 4: the middle estimate sits 1.1-fold (0.06 log units) below what was measured; the measured number falls inside the stated range.
By their numbers in this assay, from the lowest: compounds 2, 1 and 4 (each within the scatter of the next); then compound 3.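

For the compounds shown here, compound 1 to compound 4 is the first step in this set that can be read at this position, on a saturated chain carbon bound to a sulfur: in this assay it is a 1.1-fold higher number from compound 1 to compound 4 (0.03 log units; within the scatter), so this change leaves the number where it was. The swap of 5-chlorothiophen-2-yl for 4-bromothiophen-2-yl alters both the halogen and its place on the thiophene, and neither alteration, taken together with the other, produces a difference that can be told from scatter on this read-out. Nothing available explains this outcome, and no supporting measurement bears on it.

Because the halogen and its place on the thiophene change together in this one pair, the compounds shown cannot separate the two, and a chlorine moved alone or a bromine left in the original place could behave differently from this combined swap. They also leave open whether the number would hold with an amine or a carboxylic acid on the thiophene in place of the halogen, or with a longer chain between the thiophene and the sulfur.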